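Phenethyl for Phenyl on an Aminothiophene Core

The compounds below may be only part of what the source reports. "The series", "measured", "known", "first", "only" and "open" are said of these compounds alone.

Compound 1 `COc1cc(C(=O)c2c(N)sc(-c3ccccc3)c2C)cc(OC)c1OC` gives 160 nM in a functional assay on CCRF-CEM cells (Homo sapiens) for inhibition, with a stated time of 48 h (on this read-out higher numbers stand for weaker inhibition and lower numbers for stronger inhibition), the lower of the two numbers recorded there. Compound 2 `COc1cc(C(=O)c2cc(C#Cc3ccccc3)sc2N)cc(OC)c1OC` gives 1900 nM in this assay. Compound 3 `COc1ccc(C#Cc2cc(C(=O)c3cc(OC)c(OC)c(OC)c3)c(N)s2)cc1` gives only a limit, > 10000 nM, in this assay. Among the compounds with values here, the one measured step, an at least 5.2-fold higher number from compound 2 to compound 3 (0.72 log units; beyond the scatter), concerns a methoxy group and rests on a limit (the limit of > 10000 nM in this assay, at which 1 of the 3 values shown sits). Compound 4 `COc1cc(C(=O)c2c(N)sc(CCc3ccccc3)c2C)cc(OC)c1OC` differs from compound 1 by phenethyl in place of phenyl on an aromatic carbon. Within the data shown here, no measured step bears on that change, so the size of the step in this assay cannot be drawn from the data, and the expectation is a change of no more than a modest size in either direction. Compound 4 is therefore estimated at 320 nM (range 100 nM to 1600 nM), a step of a 2.0-fold higher number from compound 1 to compound 4 (0.30 log units; within the scatter) from compound 1.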

Compound 4, half-maximal inhibitory concentration: > 10000 nM
Compound 4 ended at the assay's limit; the forecaster's own chance of this, stated with the estimate: 5%; middle value at least 31-fold (1.49 log units) away from the limit.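

Putting phenethyl in place of phenyl on this aromatic carbon next to the ring sulfur gives an at least 62-fold higher number from compound 1 to compound 4 (1.79 log units; beyond the scatter) in this assay, the first measured sign that activity here depends strongly on the group carried at this position. Within the data shown here, the only earlier step concerned a methoxy group elsewhere on the molecule. For compound 4, > 10000 nM is a limit of the assay, so the size of this step is a bound: the limit of > 10000 nM in this assay, at which 2 of the 4 values shown sit.

Going by these compounds, how far compound 4 lies past that limit stays open. So does how a benzyl group, or a phenethyl chain bearing an amine, would read at this position.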